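The source may report more compounds than this note shows. Statements on the series, on what has been measured and on what is new or still open speak of the compounds shown alone.

Measured so far:
- compound 1, `C=CCc1ccc(OC(=O)C2CCCCC2)c(OC)c1`: 3.52
- compound 2, `C=CCc1ccc(OC(=O)c2cccc(F)c2)c(OC)c1`: 2.7
- compound 3, `C=CCc1ccc(OC(=O)c2ccc(C)cc2)c(OC)c1`: 2.87

All three share one core and differ only in the group attached to the carbonyl carbon of the ester. In a physicochemical assay for lipophilicity (a lower number here means a more polar compound, a higher number a more lipophilic compound), compound 3 gives 2.87, the second highest of the three numbers. Its nearest neighbour is compound 2: a number 0.17 log units higher from compound 2 to compound 3 (within the scatter), a gap within the scatter, so the two cannot be ranked against each other. Compound 1 lies furthest away: a number 0.65 log units lower from compound 1 to compound 3 (beyond the scatter).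

The next compound, compound 4, `C=CCc1ccc(OC(=O)c2ccccc2Cl)c(OC)c1`, has not yet been measured. 2-chlorophenyl in place of 4-methylphenyl on a carbonyl carbon

Among the compounds with values here, only one measured step exchanges one aromatic ring for another, a number 0.17 log units higher from compound 2 to compound 3 (within the scatter), and it stayed within the scatter. The other two steps, a number 0.82 log units lower from compound 1 to compound 2 (beyond the scatter) and a number 0.65 log units lower from compound 1 to compound 3 (beyond the scatter), replace a cyclohexyl ring by an aromatic one and so speak less directly to this change. On that basis the expected step is a number 0.02 log units lower from compound 3 to compound 4 (within the scatter), that is, no change beyond the scatter. Compound 4 is therefore estimated at 2.85, with a range from 2.45 to 3.25.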

Compound 4, partition coefficient: 2.79
For compound 4 the middle estimate is 0.06 log units above the measured one, within the range that was stated.
By their numbers in this assay, from the lowest: compounds 2, 4 and 3 (each within the scatter of the next); then compound 1.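

In this assay, 2-chlorophenyl in place of 4-methylphenyl on the carbonyl carbon gives a number 0.08 log units lower from compound 3 to compound 4 (within the scatter), and 2-chlorophenyl in place of 3-fluorophenyl gives a number 0.09 log units higher from compound 2 to compound 4 (within the scatter), so compounds 2, 3 and 4 cannot be told apart even though a chlorine-bearing ring now joins the fluorine-bearing and methyl-bearing ones. Compound 1 remains separate from all three, and the new comparison reads a number 0.73 log units lower from compound 1 to compound 4 (beyond the scatter), so among these four compounds the clear divide lies between the cyclohexyl group and the substituted phenyl groups. Nothing available here explains these numbers.

Going by these compounds, whether a phenyl ring carrying an amine or a carboxylic acid would stay with compounds 2, 3 and 4 remains open. So does where a longer chain in place of the ring would fall relative to compound 1.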